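A larger group on a series held at its limit

A few compounds are considered here, and "the series" means these few. Any claim that something is new, unique, unknown or untested is made for them only; others in the source may bear on it.

Compound 1 `Cc1cc(C)c(S(=O)(=O)N2CCC(N3CCC(C)CC3)CC2)c(C)c1`: > 5000 nM
Compound 2 `Cc1cc(C)c(S(=O)(=O)N2CCC(N3CCC(O)CC3)CC2)c(C)c1`: > 5000 nM

In an ADME assay on HCT-116 cells (Homo sapiens) for cytotoxicity, read by CellTiter-Glo, with a stated time of 72 h (a lower number here means a stronger inhibitor, a higher number a weaker inhibitor), compound 2 stands at > 5000 nM, which is a limit and not a number. Compound 1 gives > 5000 nM, also a limit. The data therefore rest on (the limit of > 5000 nM in this assay, at which 2 of the 2 values shown sit). Compound 3 `Cc1cc(C)c(S(=O)(=O)N2CCC(N3CCC(Cc4ccccc4F)CC3)CC2)c(C)c1` differs from compound 2 by one change: 2-fluorobenzyl in place of hydroxy on a saturated ring carbon. Within the data shown here, the only measured step is a step that the two limits leave unreadable from compound 1 to compound 2, so it offers no size or direction to carry over. No shift beyond the scatter is therefore expected in this assay, and the expected step is a step that the limit leaves unreadable from compound 2 to compound 3. Compound 3 is estimated at 6000 nM, within a range of 2000 nM to 20000 nM.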

Compound 3, half-maximal inhibitory concentration: > 5000 nM
Compound 3 ended at the assay's limit; the forecaster's own chance of this, stated with the estimate: 75%; the middle value does not contradict the limit.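

In this assay, among these compounds, no step among compound 1, compound 2 and compound 3 can be read, since each value is a limit and not a number. The compounds shown leave open what value each compound would actually give in this assay, and whether any group at this ring carbon changes it.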